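The source may hold more compounds than are shown below. What is called first, only, known or untested is meant among the compounds shown, and "the series" means these compounds.

Measured in a functional assay on MCF7 cells (Homo sapiens) for antiproliferative activity, read by CellTiter-Glo, with a stated time of 5 days; a higher number here means a weaker inhibitor, a lower number a stronger inhibitor:
- compound 1 `N#Cc1ccc(/C(=C(\c2ccc(/C=C/C(=O)O)cc2)c2ccc3scnc3c2)C2CCC2)c(Cl)c1`: 1.4 nM
- compound 2 `O=C(O)/C=C/c1ccc(/C(=C(\c2ccc(F)cc2Cl)C2CCC2)c2ccc3nccn3c2)cc1`: 4.4 nM

Compound 2 has the higher of the two numbers. Its nearest neighbour, compound 1 at 1.4 nM, lies lower by a gap beyond the scatter.

Compound 3 `N#Cc1ccc(/C(=C(\c2ccc(/C=C/C(=O)O)cc2)c2ccc3nccn3c2)C2CCC2)c(Cl)c1` is not yet measured and follows from compound 2 by a single change: cyano in place of fluoro on an aromatic carbon. This places cyano in place of fluoro on an aromatic carbon, turning 2-chloro-4-fluorophenyl into 2-chloro-4-cyanophenyl.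

Among the measured compounds shown here, no measured pair isolates this change, so the expectation rests on thin evidence. The 2-chloro-4-cyanophenyl group is also carried by compound 1, which gives 1.4 nM.

The estimated step of a 1.8-fold lower number from compound 2 to compound 3 (0.25 log units; within the scatter) is expected to be small, toward a lower number in this assay, and perhaps not beyond the scatter. For compound 3 the expected value is 2.5 nM, with an estimated range of 0.9 nM to 7 nM.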

Compound 3, half-maximal inhibitory concentration: 15 nM
For compound 3 the middle estimate is 6.0-fold (0.78 log units) below the measured one; the whole stated range lies below it.
By their numbers in this assay, from the lowest: compound 1; then compound 2; then compound 3.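

In this assay, cyano in place of fluoro on the ring bearing the chloro group gives a 3.4-fold higher number from compound 2 to compound 3 (0.53 log units; beyond the scatter), so with the group carried by compound 3 this change runs against the small gain that was expected. With the 2-chloro-4-cyanophenyl group held constant, exchanging the sulfur-containing group of 9 heavy atoms for the two-nitrogen group of 9 heavy atoms gives an 11-fold higher number from compound 1 to compound 3 (1.03 log units; beyond the scatter), a large step showing that the low number of compound 1 does not come with the 2-chloro-4-cyanophenyl group alone. No measurement on these compounds accounts for either step.

On these data alone, whether cyano in place of fluoro moves the number the same way alongside the sulfur-containing group remains open. Also open, as far as these compounds go, is how a methoxy group or an amine would read at this ring position.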